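The source may hold more compounds than are shown below. What is called first, only, known or untested is meant among the compounds shown, and "the series" means these compounds.

Compound 1 `CC1=CSC2=NC(/C=C/c3cccc(Cl)c3)=C(C(=O)/C=C/c3cccc(Cl)c3)C(c3ccccc3)N12`: 286 ug/mL
Compound 3 `CC1=CSC2=NC(/C=C/c3cccc(Cl)c3)=C(C(=O)/C=C/c3cccc(Cl)c3)C(c3ccc(Cl)cc3)N12`: 317 ug/mL
Compound 2 `CC1=CSC2=NC(/C=C/c3ccc(OCc4ccccc4)cc3)=C(C(=O)/C=C/c3ccc(OCc4ccccc4)cc3)C(c3ccccc3)N12`: > 500 ug/mL

In an ADME assay on Vero cells (Chlorocebus sabaeus) for cytotoxicity, read by fluorescence and resazurin assay, with a stated time of 72 h (on this read-out higher numbers stand for lower toxicity in this test and lower numbers for higher toxicity in this test), compound 1 gives 286 ug/mL and compound 3 gives 317 ug/mL. The two differ by chloro in place of hydrogen on an aromatic carbon, and this gave a 1.1-fold higher number from compound 1 to compound 3 (0.04 log units; within the scatter). Compound 2 is built on a core whose difference from the core of compound 1 is not broken down here. In this assay compound 2 gives > 500 ug/mL, which is a limit of this test rather than a number, and it is the limit of > 500 ug/mL in this assay, at which 1 of the 3 values shown sits.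

Compound 4 `CC1=CSC2=NC(/C=C/c3ccc(OCc4ccccc4)cc3)=C(C(=O)/C=C/c3ccc(OCc4ccccc4)cc3)C(c3ccc(Cl)cc3)N12` has not been measured in this assay. It differs from compound 2 by chloro in place of hydrogen on an aromatic carbon, the same change that separates compound 1 from compound 3. Since the step of a 1.1-fold higher number from compound 1 to compound 3 (0.04 log units; within the scatter) stayed within the scatter, the same change on compound 2 is expected to leave the result near where compound 2 sits, and because compound 2 stands at the limit of > 500 ug/mL in this assay, at which 1 of the 3 values shown sits, it is expected that compound 4 will also most likely be reported as a limit. The expected step is a number no higher from compound 2 to compound 4 (the limit leaves the size open). Compound 4 is therefore estimated at 500 ug/mL, within a range from 300 ug/mL to 900 ug/mL.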

Compound 4, half-maximal cytotoxic concentration: 500 ug/mL
Estimate against measurement, compound 4: no gap at the digits printed; low and high end bracket the measured number.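

In this assay the change from phenyl to 4-chlorophenyl can now be set side by side on two cores: the same change on two cores in this assay, a 1.1-fold higher number (0.04 log units; within the scatter) from compound 1 to compound 3 and a number no higher (the limit leaves the size open) from compound 2 to compound 4; the limit leaves it open whether they differ

For compound 2 the value > 500 ug/mL is a limit of the test and not a number, so the size of the step on this core cannot be read. On this core the change gave a number no higher from compound 2 to compound 4 (the limit leaves the size open). The pair on the core of compound 1 shows a step that stays within the scatter, and the second pair does not contradict it, but this does not show that the change carries over unaltered from one core to the other.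

The compounds shown leave open what other groups would do in the place of the chloro on that ring, such as a methoxy group, a nitrile or an amine. They also leave open how the same change would read on a further core, for instance one with a carboxylic acid on its outer rings, where both members of a pair give readable numbers.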